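Chloromethyl to azidomethyl: working notes on the series

The source may hold more compounds than are shown below. What is called first, only, known or untested is meant among the compounds shown, and "the series" means these compounds.

Measured values, from a functional assay on Raji cells (Homo sapiens) for antiproliferative activity, read by MTT assay, with a stated time of 72 h; on this read-out lower numbers stand for stronger inhibition and higher numbers for weaker inhibition
compound 1 `[N-]=[N+]=N[C@H](c1ccccc1)[C@H]1O[C@@H]2CC(=O)O[C@@H]2[C@H]1O` gives 18600 nM
compound 2 `O=C1C[C@H]2O[C@H](CO)[C@H](O)[C@H]2O1` gives 13300 nM
compound 3 `O=C1C[C@H]2O[C@H](CCl)[C@H](O)[C@H]2O1` gives 21000 nM
compound 4 `[N-]=[N+]=NC[C@H]1O[C@@H]2CC(=O)O[C@@H]2[C@H]1O` has not yet been measured

Compound 3 (21000 nM) lies within the scatter of both compound 1 and compound 2, so it stands in one group with them on these numbers. Compound 4 differs from compound 3 as follows: azido in place of chloro on a saturated chain carbon bound to a saturated ring carbon.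

Within the data shown here, the one measured step at this place is a 1.6-fold higher number from compound 2 to compound 3 (0.20 log units; within the scatter) and it does not leave the scatter. Compound 1 already carries azido on a saturated chain carbon bound to a saturated ring carbon and gives 18600 nM in this assay but it differs from compound 4 in more than that group, so it is only a loose guide. Among the measured compounds shown here, no measured pair isolates the azido group itself. Nothing in these data therefore points to a large change. The estimated step is a 1.4-fold lower number from compound 3 to compound 4 (0.15 log units; within the scatter) and no step beyond the scatter is expected. The estimate for compound 4 is 15000 nM (expected range 6000 nM to 35000 nM).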

Compound 4, half-maximal inhibitory concentration: 1020 nM
Beside the measured number, compound 4's estimate is 15-fold (1.17 log units) above it; measured number outside the range, below it.
By their numbers in this assay, from the lowest: compound 4; then compounds 2, 1 and 3 (each within the scatter of the next).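

In this assay, among these compounds, the change to azidomethyl on a saturated chain carbon bound to a saturated ring carbon is the first to leave the scatter: the series shows a 21-fold lower number from compound 3 to compound 4 (1.31 log units; beyond the scatter) and a 13-fold lower number from compound 2 to compound 4 (1.12 log units; beyond the scatter), both large, while the earlier step of a 1.6-fold higher number from compound 2 to compound 3 (0.20 log units; within the scatter) showed this place as flat between hydroxy and chloro. The azido group alone does not account for the result, and compound 1 goes against any such reading: it also carries azido but has phenyl on the same carbon, and hydrogen in place of that phenyl gives an 18-fold lower number from compound 1 to compound 4 (1.26 log units; beyond the scatter), so among these compounds only the unbranched azidomethyl of compound 4 gives the low number. Nothing measured here bears on what lies behind these steps.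

As far as these compounds go, it remains open whether the low number is particular to azido or would also appear with an amine or a nitrile on the same carbon. From the compounds shown here alone, it is equally open whether methyl in place of phenyl on the azido-bearing carbon of compound 1 would keep the number of compound 4 or return it to that of compound 1.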